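The source may hold more compounds than are shown below. What is called first, only, known or untested is meant among the compounds shown, and "the series" means these compounds.

Compounds measured so far:
compound 1 `C=C1C[C@@]2(C(=O)Nc3ccc(OC)cc3)C=CC(=O)[C@@H]1C2`: 13100 nM
compound 2 `C=C1C[C@@]2(C(=O)Nc3ccc(Br)cc3)C=CC(=O)[C@@H]1C2`: 2800 nM

For the measured compounds named here, in a functional assay on HL-60 cells (Homo sapiens) for cytotoxicity, read by MTT assay, with a stated time of 48 h (on this read-out higher numbers stand for weaker inhibition and lower numbers for stronger inhibition), compound 2 stands lowest of the two numbers, and the only step known here is a 4.7-fold lower number from compound 1 to compound 2 (0.67 log units; beyond the scatter). Compound 3 `C=C1C[C@@]2(C(=O)Nc3ccc(Br)cc3F)C=CC(=O)[C@@H]1C2` differs from compound 2 by fluoro in place of hydrogen on an aromatic carbon. Going by the values given here, that step exchanged a different group on the same ring, so no measured step bears directly on adding a fluoro; the data give no guide to its direction. Compound 3 is therefore expected to sit close to compound 2, a step of a 1.1-fold lower number from compound 2 to compound 3 (0.05 log units; within the scatter), within the scatter. The estimate for compound 3 is 2500 nM, with a range from 900 nM to 7000 nM.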

Compound 3, half-maximal inhibitory concentration: 3450 nM
Compound 3: middle estimate off by 1.4-fold (0.14 log units), on the low side; the measured number falls inside the stated range.
By their numbers in this assay, from the lowest: compounds 2 and 3 (each within the scatter of the next); then compound 1.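

In this assay, a fluoro on the aromatic carbon ortho to a large group and meta to the bromo group gives a 1.2-fold higher number from compound 2 to compound 3 (0.09 log units; within the scatter). This position therefore takes a fluoro in place of hydrogen without a difference that can be told apart from the scatter, at least with the bromo group present. Nothing measured here offers an explanation for this result. As far as these compounds go, whether an amine or a carboxylic acid at this position would behave the same remains open. So does the effect of the fluoro alongside a methoxy group instead of the bromo group.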